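The source may hold more compounds than are shown below. What is called first, only, known or untested is meant among the compounds shown, and "the series" means these compounds.

Compound 1, `CN(C)C(=O)c1cccnc1NCCCN1CCN(c2ccccc2OC(F)(F)F)CC1`, gives 100 nM in a functional assay on aorta for antagonist activity at Alpha-1D adrenergic receptor (Rattus norvegicus); on this read-out lower numbers stand for tighter binding and higher numbers for weaker binding. Compound 2, `CN(C)C(=O)c1cccnc1NCCCN1CCN(c2ccccc2-c2ccccc2)CC1`, gives 63.1 nM in this assay. Compound 3, `CSc1ccccc1N1CCN(CCCNc2ncccc2C(=O)N(C)C)CC1`, gives 31.6 nM in this assay.

Compound 3 stands at the lowest number of the three. Its separation from compound 1 is clear, the step being a 3.2-fold lower number from compound 1 to compound 3 (0.50 log units; beyond the scatter), whereas the step of a 2.0-fold lower number from compound 2 to compound 3 (0.30 log units; within the scatter) and the step of a 1.6-fold lower number from compound 1 to compound 2 (0.20 log units; within the scatter) both stay within the usual scatter, so compound 2 and compound 3 cannot be ranked against each other.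

Compound 4, `CN(C)C(=O)c1cccnc1NCCCN1CCN(c2ccccc2Cc2ccccc2)CC1`, has not yet been measured in this assay. It differs from compound 3 in a single place: benzyl in place of methylsulfanyl on an aromatic carbon. Of the measured steps, the one that bears most directly on this change is a 2.0-fold lower number from compound 2 to compound 3 (0.30 log units; within the scatter), where a phenyl stood in the same place as the incoming benzyl; the step of a 3.2-fold lower number from compound 1 to compound 3 (0.50 log units; beyond the scatter) bears on it only in that the same methylsulfanyl leaves. Read backwards, the phenyl comparison points to a modest rise in the number, probably within the scatter.

Compound 4 is therefore expected to come in at about 56 nM, with a plausible range from 25 nM to 125 nM. This estimate corresponds to a step of a 1.8-fold higher number from compound 3 to compound 4 (0.25 log units; within the scatter), which is expected to stay within the scatter.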

Compound 4, dissociation constant: 79.4 nM
Estimate against measurement, compound 4: 1.4-fold (0.15 log units) below; the measured number falls inside the stated range.
By their numbers in this assay, from the lowest: compounds 3, 2, 4 and 1 (each within the scatter of the next, the first and the last beyond it).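

Benzyl is the first group carrying a ring of carbon to stand clearly apart from methylsulfanyl on this aromatic carbon, with a 2.5-fold higher number from compound 3 to compound 4 (0.40 log units; beyond the scatter); phenyl had not done so, given a 2.0-fold lower number from compound 2 to compound 3 (0.30 log units; within the scatter). Together with trifluoromethoxy in compound 1, this makes two of the three other groups that separate from methylsulfanyl, with compound 2 the one that goes against this pattern. The other two new steps show no such separation among the remaining groups: a 1.3-fold higher number from compound 2 to compound 4 (0.10 log units; within the scatter) and a 1.3-fold lower number from compound 1 to compound 4 (0.10 log units; within the scatter) both leave benzyl indistinguishable from phenyl and from trifluoromethoxy, so inserting a single carbon between the ring and the aromatic carbon, as benzyl does relative to phenyl, has no readable effect here, and the three groups cannot be ranked against one another.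

The compounds shown leave open whether the edge held by compound 3 belongs to the sulfur itself, which a methoxy, an ethylsulfanyl or a plain methyl at the same place would test, and whether a phenethyl, with its longer chain, would still fall in with benzyl and phenyl. Nothing given here accounts for the size of any of these steps.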